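A few compounds are considered here, and "the series" means these few. Any claim that something is new, unique, unknown or untested is made for them only; others in the source may bear on it.

Compound 1 `CC1=C(C(=O)OCC(C)C)C(c2ccoc2)NC(=O)N1`: 326 nM
Compound 2 `CC1=C(C(=O)CC(C)C)C(c2ccoc2)NC(=O)N1`: 1010 nM
Compound 3 `CC1=C(C(=O)CC(C)C)C(c2ccsc2)NC(=O)N1`: 1000 nM

In an assay on membranes from HEK293 cells for displacement of a labelled ligand from adenosine receptor A2b (Homo sapiens), read by scintillation counting, with a stated time of 30 min (on this read-out higher numbers stand for weaker inhibition and lower numbers for stronger inhibition), compound 2 stands at the highest number of the three. Compound 3 sits within the scatter of it: a 1.0-fold lower number from compound 2 to compound 3 (0.00 log units; within the scatter). Compound 1 sits clearly lower, since a 3.1-fold higher number from compound 1 to compound 2 (0.49 log units; beyond the scatter).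

Compound 4 `CC1=C(c2ncc(C)o2)C(c2ccoc2)NC(=O)N1` differs from compound 2 by 5-methyl-1,3-oxazol-2-yl in place of isobutylcarbonyl on a double-bonded ring carbon. Neither measured step bears on this directly: the step from compound 1 to compound 2 altered the same position only by swapping isobutoxy for isobutyl, and the step from compound 2 to compound 3 touched another ring. As far as these compounds go, the change to an aromatic ring at this position is untested here, so no step beyond the scatter is expected, with wide uncertainty: a 1.0-fold lower number from compound 2 to compound 4 (0.00 log units; within the scatter). Compound 4 is estimated at 1000 nM, in the range 250 nM to 4000 nM.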

Compound 4, inhibition constant: 801 nM
Beside the measured number, compound 4's estimate is 1.2-fold (0.10 log units) above it; low and high end bracket the measured number.
By their numbers in this assay, from the lowest: compound 1; then compounds 4, 3 and 2 (each within the scatter of the next).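

In this assay, replacing isobutylcarbonyl on the double-bonded ring carbon with 5-methyl-1,3-oxazol-2-yl leaves the number within the scatter: a 1.3-fold lower number from compound 2 to compound 4 (0.10 log units; within the scatter). For the compounds shown here, this position, previously seen only with the swap of isobutoxy for isobutyl, therefore also tolerates an aromatic ring, and the carbonyl of compound 2 is not needed to stay at this level. Nothing measured here explains why the two groups read alike.

As far as these compounds go, it remains open whether a phenyl ring, an unsubstituted oxazole or an amine at this position would stay at this level or come closer to compound 1 at 326 nM.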